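Working notes on cytotoxicity: from compound 1 to compound 4

A few compounds are considered here, and "the series" means these few. Any claim that something is new, unique, unknown or untested is made for them only; others in the source may bear on it.

In an ADME assay on Huh-7 cells (Homo sapiens) for cytotoxicity, read by MTT assay, with a stated time of 72 h (a higher number here means that more compound is tolerated, a lower number that less compound is tolerated), compound 1 `Cc1cc(=O)oc2cc(OCc3cn(-c4ccc(F)cc4)nn3)ccc12` gives > 100 ug/mL, which is a limit of the assay and not a number. Compound 2 `Cc1cc(=O)oc2cc(OCc3cn(-c4ccc(Cl)cc4)nn3)ccc12` gives > 100 ug/mL, also a limit. Compound 3 `Cc1ccc(-n2cc(COc3ccc4c(C)cc(=O)oc4c3)nn2)c(Cl)c1` gives > 100 ug/mL, again a limit. The steps a step that the two limits leave unreadable from compound 1 to compound 2, a step that the two limits leave unreadable from compound 1 to compound 3 and a step that the two limits leave unreadable from compound 2 to compound 3 thus carry no readable size, as all three values sit at the limit of > 100 ug/mL in this assay, at which 3 of the 3 values shown sit. Compound 4 `Cc1cc(=O)oc2cc(OCc3cn(CCO)nn3)ccc12` differs from compound 1 in one place: 2-hydroxyethyl in place of 4-fluorophenyl on an aromatic nitrogen. For the measured compounds named here, none of the measured steps touches this group, so they give no size for the change in this assay. The expectation is that compound 4 also stays at the limit, so the step that the limit leaves unreadable from compound 1 to compound 4 is expected to be unreadable or within the scatter. Compound 4 is estimated at 150 ug/mL, between 60 ug/mL and 400 ug/mL.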

Compound 4, half-maximal cytotoxic concentration: > 100 ug/mL
Compound 4 was reported as a limit (the forecaster's own chance of this, stated with the estimate: 80%); the middle value is on the limit's open side.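

Compound 4 is reported as a limit in this assay, so no step from compound 1, compound 2 or compound 3 to compound 4 can be read: the limit of > 100 ug/mL in this assay, at which 4 of the 4 values shown sit.

The compounds shown leave open how far any group on the aromatic nitrogen shifts the half-maximal cytotoxic concentration.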